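The source may report more compounds than this note shows. Statements on the series, on what has been measured and on what is new or still open speak of the compounds shown alone.

Measured so far:
compound 1 `CN(C(=O)c1ccccc1)c1ccc2[nH]c(-c3n[nH]c4ccccc34)cc2n1`, 10600 nM
compound 2 `CN(C(=O)c1ccccc1)c1ccc2[nH]c(-c3n[nH]c4cc(Cl)ccc34)cc2n1`, 13100 nM

Both numbers come from a functional assay on HCT-116 cells (Homo sapiens) for antiproliferative activity, read by MTT assay, with a stated time of 72 h; a lower number here means a stronger inhibitor, a higher number a weaker inhibitor. Compound 1 gives the lower of the two numbers, but compound 2 sits close to it: a 1.2-fold higher number from compound 1 to compound 2 (0.09 log units; within the scatter). Going by the values given here, that is the only step in hand, and it concerns chloro in place of hydrogen on an aromatic carbon, a different place from the one now in question.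

Compound 3 `CN(C(=O)Nc1ccccc1)c1ccc2[nH]c(-c3n[nH]c4ccccc34)cc2n1` differs from compound 1 by anilino in place of phenyl on a carbonyl carbon. Among the compounds with values here, no measured pair changes the group on the carbonyl carbon, so nothing here bears directly on this step; the one step known, from compound 1 to compound 2, was within the scatter and lies elsewhere in the molecule. Within the data shown here, with no precedent, no step beyond the scatter is expected in either direction, and the uncertainty is taken wide.

For compound 3 in this assay the estimate is 10000 nM, with a range from 2500 nM to 40000 nM. That estimate corresponds to an expected step of a 1.1-fold lower number from compound 1 to compound 3 (0.03 log units; within the scatter).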

Compound 3, half-maximal inhibitory concentration: 1.3 nM
The estimate for compound 3 lay 7700-fold (3.89 log units) above the measured number; measured number outside the range, below it.
By their numbers in this assay, from the lowest: compound 3; then compounds 1 and 2 (each within the scatter of the next).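

In this assay, going by these compounds alone, the group on the carbonyl carbon is the first place where a change moves the number beyond the scatter: anilino in place of phenyl gives an 8200-fold lower number from compound 1 to compound 3 (3.91 log units; beyond the scatter), whereas the chloro change gave only a 1.2-fold higher number from compound 1 to compound 2 (0.09 log units; within the scatter). The entering anilino keeps the six-membered aromatic ring and adds a nitrogen bearing a hydrogen-bond donor, so the step belongs to that nitrogen together with its hydrogen, not to a change of ring. No measurement shown here explains the size of this step.

Still open, as far as these compounds go, is whether the anilino hydrogen is required, or whether a methylated anilino or a cyclohexylamino group on the same carbonyl carbon would keep the low number. Also open, from the compounds shown here alone, is whether chloro on the core stays within the scatter when anilino is present.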